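The source may hold more compounds than are shown below. What is called first, only, known or untested is meant among the compounds shown, and "the series" means these compounds.

Compound 1 `Oc1c(C(Nc2ccccc2)c2ccccc2)ccc2ccccc12` and compound 2 `O=C(O)c1cccc(NC(c2ccccc2)c2ccc3ccccc3c2O)c1` share a core and differ by one change, (carboxy in place of hydrogen on an aromatic carbon), which sits meta to a large group. In an assay on isolated protein for inhibition of CAAX prenyl protease 2 (Homo sapiens), with stated times of 60 s and 60 min (on this read-out lower numbers stand for stronger inhibition and higher numbers for weaker inhibition), compound 1 gives 4900 nM, and compound 2 gives 5300 nM; the step is a 1.1-fold higher number from compound 1 to compound 2 (0.03 log units; within the scatter). Compound 3 `Oc1c(C(Nc2ccccc2)c2c(F)cc(Br)cc2F)ccc2ccccc12` carries a different core, set apart from that of compound 1 by 4-bromo-2,6-difluorophenyl in place of phenyl on a saturated chain carbon bound to an aromatic carbon and a nitrogen on an aromatic ring; in this assay compound 3 gives 9400 nM, with a step of a 1.9-fold higher number from compound 1 to compound 3 (0.28 log units; within the scatter). Compound 4 `O=C(O)c1ccc(NC(c2ccc3ccccc3c2O)c2c(F)cc(Br)cc2F)cc1` has not yet been measured. Among the compounds with values here, it differs from compound 3 by carboxy in place of hydrogen on an aromatic carbon, which sits para to a large group, so it is the same kind of change as the one from compound 1 to compound 2, though not at the same place. Since the earlier carboxy step stayed within the scatter, a step of about a 1.1-fold higher number from compound 3 to compound 4 (0.03 log units; within the scatter) is expected here as well, resting only on that single earlier step and on the modest difference between the two cores. Compound 4 is therefore estimated to give 10000 nM, with a likely range from 4500 nM to 22000 nM.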

Compound 4, half-maximal inhibitory concentration: 3800 nM
Beside the measured number, compound 4's estimate is 2.6-fold (0.42 log units) above it; measured number outside the range, below it.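

The carboxy change does not behave alike on the two cores: in this assay it now gives a 2.5-fold lower number from compound 3 to compound 4 (0.39 log units; beyond the scatter), whereas the earlier carboxy step stayed within the scatter, and the two steps differ by more than repeat measurements would account for: the same change on two cores in this assay, a 1.1-fold higher number (0.03 log units; within the scatter) from compound 1 to compound 2 and a 2.5-fold lower number (0.39 log units; beyond the scatter) from compound 3 to compound 4, 2.7-fold (0.43 log units) apart, beyond the scatter of two such steps. The size of this change, measured on the core of compound 1, therefore cannot simply be carried over to the core of compound 3. This does not show what sets the two steps apart, since they differ in the core and also in where the carboxy sits on the ring, and a single pair of steps makes no general rule for the series.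

A carboxy group at the same place on both cores would separate the effect of the core from that of the position. Within the data shown here, it also stays open whether another group at that place, such as a methyl ester or a primary amide, would give a step like the one seen with compound 4.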